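Methyl in place of phenoxy: a first small group

A few compounds are considered here, and "the series" means these few. Any claim that something is new, unique, unknown or untested is made for them only; others in the source may bear on it.

In a functional assay on MCF7 cells (Homo sapiens) for inhibition, read by sulforhodamine B assay, with a stated time of 48 h (a lower number here means a stronger inhibitor of growth, a higher number a weaker inhibitor of growth), compound 1 (`O=C(CCl)NC(=O)Nc1ccc(C2CCCCC2)cc1`) gives 1500 nM and compound 2 (`O=C(CCl)NC(=O)Nc1ccc(Oc2ccccc2)cc1`) gives 4200 nM as the higher of the two numbers. Compound 3 (`Cc1ccc(NC(=O)NC(=O)CCl)cc1`) differs from compound 2 at one place: methyl in place of phenoxy on an aromatic carbon. Going by the values given here, the only measured step at this place is a 2.8-fold higher number from compound 1 to compound 2 (0.45 log units; beyond the scatter) and is modest. Among the compounds with values here, no measured compound carries a group as small as methyl, so the direction remains uncertain. A modest rise is expected, with the estimated step being a 2.1-fold higher number from compound 2 to compound 3 (0.33 log units; beyond the scatter) in this assay overall. For compound 3 the estimated value is 9000 nM (expected range 3000 nM to 30000 nM).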

Compound 3, concentration for 50% growth inhibition: 7500 nM
Beside the measured number, compound 3's estimate is 1.2-fold (0.08 log units) above it; the measured number falls inside the stated range.
By their numbers in this assay, from the lowest: compound 1; then compounds 2 and 3 (each within the scatter of the next).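

In this assay, methyl in place of phenoxy gives a 1.8-fold higher number from compound 2 to compound 3 (0.25 log units; within the scatter), so this change cannot be read as an effect at this position. Cyclohexyl alone stands apart from methyl, with a 5.0-fold higher number from compound 1 to compound 3 (0.70 log units; beyond the scatter), and group size alone does not order the series, with compound 2 going against such a trend. Nothing at hand gives a reason for this separation. Open, on these data alone, is how an amine, a carboxylic acid or a longer alkyl chain would read at this position.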